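Replacing dimethylamino by amino on a deoxynucleoside core

The source may hold more compounds than are shown below. What is called first, only, known or untested is meant among the compounds shown, and "the series" means these compounds.

Compound 1 `CNc1nc(SC)nc2c1ncn2[C@@H]1C[C@@H](O)[C@H](CO)O1` — in a functional assay on HL-60 cells (Homo sapiens) (on this read-out higher numbers stand for weaker inhibition and lower numbers for stronger inhibition), compound 1 gives > 300 uM, a limit of the assay.
Compound 2 `CSc1nc(N(C)C)c2ncn([C@@H]3C[C@@H](O)[C@H](CO)O3)c2n1` — in this assay compound 2 gives > 300 uM, a limit of the assay.

Compound 2 stands at the limit of this assay rather than at a number. Going by the values given here, the only measured step, a step that the two limits leave unreadable from compound 1 to compound 2, is left unreadable by the two limits, so it gives no direction for the change now followed. The condition at which both values sit is described by the limit of > 300 uM in this assay, at which 2 of the 2 values shown sit.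

Compound 3 `CSc1nc(N)c2ncn([C@@H]3C[C@@H](O)[C@H](CO)O3)c2n1` has not been measured in this assay. It differs from compound 2 by amino in place of dimethylamino on an aromatic carbon. Among the compounds with values here, no measured step speaks directly to this change; the only comparison available, that from compound 1 to compound 2, is unreadable. With both measured compounds at the limit, the expectation for compound 3 can rest only on that: compound 3 is estimated to be likely to sit at the limit again, and any step a number no higher from compound 2 to compound 3 (the limit leaves the size open) is expected to be at most small. The estimate for compound 3 in this assay is 300 uM, with a range from 80 uM to 1000 uM.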

Compound 3, concentration for 50% inhibition: > 300 uM
Compound 3: only a limit was reported (the forecaster's own chance of this, stated with the estimate: 70%); the middle value sits exactly at the limit.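

In this assay compound 3 gives > 300 uM, a limit of the assay. Its steps from compound 1 and from compound 2 therefore cannot be read, and all the values share one condition: the limit of > 300 uM in this assay, at which 3 of the 3 values shown sit.

The compounds shown leave open how far each lies from that limit, and so whether amino in place of dimethylamino changes inhibition at all.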